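Swapping the Aryl Ether Ring and Cytotoxicity in Cells

The source may hold more compounds than are shown below. What is called first, only, known or untested is meant among the compounds shown, and "the series" means these compounds.

Of the compounds shown here, three have been measured in an ADME assay on MT4 cells (Homo sapiens) for cytotoxicity, read by MTT assay, with a stated time of 5 days; on this read-out higher numbers stand for lower toxicity in this test and lower numbers for higher toxicity in this test. Compound 1 `Cc1cc(C)c(Oc2cc(NCCn3ccc(=O)[nH]c3=O)nc(Cl)n2)c(C)c1` gives 76400 nM. Compound 3 `Cc1cc(C)c(Oc2nc(NCCn3ccc(=O)[nH]c3=O)ncc2Cl)c(C)c1` gives 2490 nM. Compound 2 `Cc1cc(C)cc(Oc2nc(NCCn3ccc(=O)[nH]c3=O)ncc2Cl)c1` gives > 322000 nM in this assay, which is a limit and not a number. Compounds 1 and 3 are built from the same atoms joined differently; the difference between the two cores is not broken down here. From compound 3 to compound 2 the change is 3,5-dimethylphenyl in place of 2,4,6-trimethylphenyl on an oxygen on an aromatic ring, and an at least 120-fold higher number from compound 3 to compound 2 (2.11 log units; beyond the scatter). Compound 4 `Cc1cc(C)cc(Oc2cc(NCCn3ccc(=O)[nH]c3=O)nc(Cl)n2)c1` has not yet been measured; it differs from compound 1 by 3,5-dimethylphenyl in place of 2,4,6-trimethylphenyl on an oxygen on an aromatic ring, the same change. Since the earlier step ran into the ceiling (the limit of > 322000 nM in this assay, at which 1 of the 3 values shown sits), the step from compound 1 to compound 4 is expected to be a 5.2-fold higher number from compound 1 to compound 4 (0.72 log units; beyond the scatter). Compound 4 is therefore expected to give 400000 nM, most likely recorded only as a limit.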

Compound 4, half-maximal cytotoxic concentration: 99500 nM
Compound 4: middle estimate off by 4.0-fold (0.60 log units), on the high side; the whole stated range lies above it.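

In this assay, replacing the ring on the oxygen gives a 1.3-fold higher number from compound 1 to compound 4 (0.11 log units; within the scatter), so on this core the two rings cannot be told apart. The same change therefore does not carry over from one core to the other in this series, and the size of its effect depends on the core that carries it: the same change on two cores in this assay, an at least 120-fold higher number (2.11 log units; beyond the scatter) from compound 3 to compound 2 and a 1.3-fold higher number (0.11 log units; within the scatter) from compound 1 to compound 4, at least 99-fold (1.99 log units) apart, beyond the scatter of two such steps The larger step ends in a limit, held by compound 2, and two pairs do not show what in the cores makes the difference: the limit of > 322000 nM in this assay, at which 1 of the 4 values shown sits.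

Going by these compounds, it remains open how this read-out responds when the ring on the oxygen carries a nitrile or a methoxy group instead of methyl groups. On these data alone, it also remains open which of the two steps a third core would resemble.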